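The source may report more compounds than this note shows. Statements on the series, on what has been measured and on what is new or still open speak of the compounds shown alone.

Series notes, aryl variation on the shared core.

Among the compounds with values here, the three measured members are compound 1 `Brc1cn2ccnc2c(-c2ccc3ncn(C4CCCCC4)c3c2)n1`, compound 2 `O=Cc1ccc(-c2cn3ccnc3c(-c3ccc4ncn(C5CCCCC5)c4c3)n2)cc1` and compound 3 `COc1ccccc1-c1cn2ccnc2c(-c2ccc3ncn(C4CCCCC4)c3c2)n1`. In a functional assay on SNB-75 cells (Homo sapiens) for inhibition, read by sulforhodamine B assay, with a stated time of 48 h, tested at 10 uM (on this read-out higher numbers stand for more inhibition at the one concentration tested (going by the name of the read-out) and lower numbers for less inhibition), compound 1 gives 21.3%, compound 2 gives 21.4% and compound 3 gives 35%. Compound 2 thus sits second of the three numbers, but its gap to compound 1 is within the scatter and only compound 3 stands apart from it, beyond the scatter.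

The unmeasured compound 4 `Fc1ccccc1-c1cn2ccnc2c(-c2ccc3ncn(C4CCCCC4)c3c2)n1` differs from compound 2 in one place: 2-fluorophenyl in place of 4-formylphenyl on an aromatic carbon.

Within the data shown here, two measured steps bear on this. The step of a number 0.1 percentage points higher from compound 1 to compound 2 (within the scatter) shows the 4-formylphenyl group adding nothing beyond the scatter over bromo. The step of a number 13.6 percentage points higher from compound 2 to compound 3 (beyond the scatter) and the step of a number 13.7 percentage points higher from compound 1 to compound 3 (beyond the scatter) show that a 2-methoxyphenyl group in the same place gives a modest rise. Compound 4 carries a 2-fluorophenyl group, which resembles the 2-methoxyphenyl of compound 3 more than the 4-formylphenyl of compound 2, so a modest upward step is expected, though smaller and less certain than that seen for compound 3.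

For compound 4 a value of 30% is estimated in this assay, with a range from 15% to 45%, which would mean an expected step of a number 8.6 percentage points higher from compound 2 to compound 4 (within the scatter).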

Compound 4, a percentage reported as inhibition, at one concentration (the size of the read-out at that concentration, not a potency): 29.7%
Estimate against measurement, compound 4: 0.3 percentage points above, within the range that was stated.
By their numbers in this assay, from the lowest: compounds 1, 2, 4 and 3 (each within the scatter of the next, the first and the last beyond it).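

The step of a number 8.3 percentage points higher from compound 2 to compound 4 (within the scatter) and the step of a number 8.4 percentage points higher from compound 1 to compound 4 (within the scatter) and the step of a number 5.3 percentage points lower from compound 3 to compound 4 (within the scatter) together place compound 4 within the scatter of all three earlier members in this assay, even though compound 3 stands apart from compounds 1 and 2. The series at this position therefore no longer divides cleanly into two levels, and the 2-fluorophenyl group fills the gap without being separable from either side. Exchanging methoxy for fluoro on the 2-substituted phenyl leaves the read-out within the scatter, so these two groups cannot be told apart at this position, and nothing shown gives a reason for any of these numbers.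

Going by these compounds, whether the rise in compound 3 comes from the kind of substituent on the phenyl or from where it sits remains open, since 4-formylphenyl and the two 2-substituted phenyl groups differ in both respects. Also open, on these data alone, is how this position responds to a phenyl bearing an amine or a carboxylic acid, and whether any of these single-concentration differences would hold up as a difference in potency.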